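Adding chloro to a tolerated sulfonamide

A few compounds are considered here, and "the series" means these few. Any claim that something is new, unique, unknown or untested is made for them only; others in the source may bear on it.

Three sulfonamides sharing one core have been tested in an ADME assay on A549 cells (Homo sapiens) for cytotoxicity, read by MTT assay; a lower number here means that less compound is tolerated, a higher number that more compound is tolerated. Compound 1 `Cc1ccccc1N(C)S(=O)(=O)c1cc(Cl)ccc1Cl` gives only a limit of the assay, > 5000 nM. Compound 2 `C=CCN(c1ccccc1C)S(=O)(=O)c1cc(Cl)ccc1Cl` likewise gives only a limit, > 5000 nM. Compound 3 `Cc1ccccc1N(C(C)C)S(=O)(=O)c1cc(Cl)ccc1Cl` also gives only a limit, > 5000 nM. The steps a step that the two limits leave unreadable from compound 1 to compound 2, a step that the two limits leave unreadable from compound 1 to compound 3 and a step that the two limits leave unreadable from compound 2 to compound 3 cannot be sized because of the limit of > 5000 nM in this assay, at which 3 of the 3 values shown sit. Compound 4 `C=CCN(c1ccc(Cl)cc1C)S(=O)(=O)c1cc(Cl)ccc1Cl` differs from compound 2 by chloro in place of hydrogen on an aromatic carbon. Among the measured compounds shown here, none of the measured steps touches that aromatic position, so no measured step bears on it, and the three limits give no direction. Compound 4 is therefore expected to give 5000 nM in this assay, within 2000 nM to 12000 nM, an expected step of a number no higher from compound 2 to compound 4 (the limit leaves the size open) that stays within the scatter.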

Compound 4, half-maximal cytotoxic concentration: > 5000 nM
Compound 4: a limit, no number; the forecaster's own chance of this, stated with the estimate: 70%; the middle value sits exactly at the limit.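

Compound 4, like compound 2, gives only a limit in this assay, so the step between them cannot be read: the limit of > 5000 nM in this assay, at which 4 of the 4 values shown sit. The compounds shown leave open what concentration any of the four takes to reach half-maximal cytotoxicity, and so whether chloro changes it.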